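Aryl groups on the ring nitrogen of the shared core

The compounds below may be only part of what the source reports. "The series", "measured", "known", "first", "only" and "open" are said of these compounds alone.

Measured compounds:
compound 1, `C#CCSc1nc(NCCC(C)C)c2ccncc2n1`: > 80000 nM
compound 2, `C#CCSc1nc(Nc2ccc(F)cc2)c2ccncc2n1`: 10800 nM
compound 3, `C#CCSc1nc(Nc2cccc(Cl)c2)c2ccncc2n1`: 1090 nM

In a functional assay on HepG2 cells (Homo sapiens) for inhibition, read by MTT assay, with a stated time of 72 h (on this read-out lower numbers stand for stronger inhibition and higher numbers for weaker inhibition), compound 1 gives only a limit, > 80000 nM, which is the limit of > 80000 nM in this assay, at which 1 of the 3 values shown sits. Compound 4, `C#CCSc1nc(Nc2ccc(O)cc2)c2ccncc2n1`, differs from compound 1 by 4-hydroxyphenyl in place of isopentyl on a nitrogen on an aromatic ring. The two measured steps that bear on it are an at least 7.4-fold lower number from compound 1 to compound 2 (0.86 log units; beyond the scatter) and an at least 73-fold lower number from compound 1 to compound 3 (1.86 log units; beyond the scatter), both of them beyond the scatter; the further step a 9.9-fold lower number from compound 2 to compound 3 (1.00 log units; beyond the scatter) shows how much the pattern on the entering ring matters. The 4-hydroxyphenyl group, like 4-fluorophenyl, carries its substituent on the same ring position named in its group name, so a step of the size seen for compound 2 is expected: an at least 6.6-fold lower number from compound 1 to compound 4 (0.82 log units; beyond the scatter). Compound 4 is therefore estimated at 12000 nM, with a range from 3000 nM to 50000 nM.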

Compound 4, half-maximal inhibitory concentration: > 80000 nM
Compound 4: no number, only a limit (the forecaster's own chance of this, stated with the estimate: 15%); middle value at least 6.6-fold (0.82 log units) away from the limit.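

Hydroxy in place of fluoro on an aromatic carbon gives an at least 7.4-fold higher number from compound 2 to compound 4 (0.86 log units; beyond the scatter), which shows that an aromatic ring on this nitrogen does not by itself secure a measurable number. Set against the 3-chlorophenyl group, the 4-hydroxyphenyl group gives an at least 73-fold higher number from compound 3 to compound 4 (1.86 log units; beyond the scatter). In this assay compound 4 gives only a limit, as compound 1 does, and the step between those two cannot be read: the limit of > 80000 nM in this assay, at which 2 of the 4 values shown sit.

The compounds shown leave open whether a methoxy group or an amine in place of the hydroxy would bring back a measurable number. They also leave open how 3-hydroxyphenyl would compare with 3-chlorophenyl.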